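Changing the Urea Cap: From Compound 3 to Compound 4

The compounds below may be only part of what the source reports. "The series", "measured", "known", "first", "only" and "open" are said of these compounds alone.

Of the compounds shown here, three sharing one core have been measured in an assay on isolated protein for inhibition of serine/threonine-protein kinase PLK1 (Homo sapiens), read by radiometric assay and 33P incorporation, with a stated time of 40 min, tested at 20 uM, in the presence of a further agent that is not named here; a lower number here means less inhibition, a higher number more inhibition at the concentration tested (going by the name of the read-out). Compound 1 `CCNc1cc(-c2ccc(NC(=O)Nc3ccc(OC)cc3)cc2C)ccn1` gives 45.8%, and compound 2 `CCNc1cc(-c2ccc(NC(=O)Nc3ccc(C(F)(F)F)cc3)cc2C)ccn1` gives 54.8% in this assay. Compound 3 `CCNc1cc(-c2ccc(NC(=O)Nc3c(C)cccc3C)cc2C)ccn1` gives 42.1% in this assay, the lowest of the three numbers, though the step of a number 3.7 percentage points lower from compound 1 to compound 3 (within the scatter) stays within the scatter and only a number 12.7 percentage points lower from compound 2 to compound 3 (beyond the scatter) goes beyond it. The step of a number 9 percentage points higher from compound 1 to compound 2 (within the scatter) is also within the scatter.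

Compound 4 `CCNc1cc(-c2ccc(NC(=O)Nc3ccccc3Cl)cc2C)ccn1` differs from compound 3 in one place: 2-chlorophenyl in place of 2,6-dimethylphenyl on an amide-type nitrogen. The two measured steps that exchange the group on this amide-type nitrogen bear on this change: a number 3.7 percentage points lower from compound 1 to compound 3 (within the scatter) was small and a number 12.7 percentage points lower from compound 2 to compound 3 (beyond the scatter) was modest. Exchanging that group has therefore moved this assay only a little so far, so a small step in either direction, or none beyond the scatter, is expected. Compound 4 is expected to give about 47% in this assay, within a range from 30% to 64%, meaning an expected step of a number 4.9 percentage points higher from compound 3 to compound 4 (within the scatter).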

Compound 4, a percentage reported as inhibition, at one concentration (the size of the read-out at that concentration, not a potency): 49.2%
For compound 4 the middle estimate is 2.2 percentage points below the measured one; the range from low to high includes it.
By their numbers in this assay, from the lowest: compounds 3, 1, 4 and 2 (each within the scatter of the next, the first and the last beyond it).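

In this assay, the three new steps are a number 7.1 percentage points higher from compound 3 to compound 4 (within the scatter), a number 5.6 percentage points lower from compound 2 to compound 4 (within the scatter) and a number 3.4 percentage points higher from compound 1 to compound 4 (within the scatter), so 2-chlorophenyl on the amide-type nitrogen cannot be told apart from any of the three earlier groups. Compound 4 therefore adds a fourth aromatic group that stays within the scatter of each of the others, and the step from compound 2 to compound 3 remains the only one that goes beyond it. Nothing measured here gives a reason for the size of these steps.

As far as these compounds go, these numbers are read at one concentration, so how the four compounds compare in potency remains open. Also open, from the compounds shown here alone, is whether a cyclohexyl group, or a phenyl ring carrying an amine or a carboxylic acid, on this nitrogen would move the number beyond the scatter.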